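Spiro-fused cyclohexyl amide in the oxadiazole–azetidine series

The compounds below may be only part of what the source reports. "The series", "measured", "known", "first", "only" and "open" are said of these compounds alone.

Measured so far:
- compound 1 `O=C(c1ccc(Cl)cc1)N1CC(c2nc(-c3cccc(F)c3)no2)C1` — 2500 nM
- compound 2 `CC1CCC(C(=O)N2CC(c3nc(-c4cccc(Cl)c4)no3)C2)CC1` — 1500 nM
- compound 3 `O=C(C1CCC(C(F)(F)F)CC1)N1CC(c2nc(-c3cccc(Cl)c3)no2)C1` — 1000 nM

In an assay on HEK293 cells for positive allosteric modulation of metabotropic glutamate receptor 5 (Homo sapiens), read by FLIPR (on this read-out lower numbers stand for an effect already at smaller amounts and higher numbers for an effect only at larger amounts of compound), compound 2 gives 1500 nM, the second highest of the three numbers; its nearest neighbour is compound 3 and its furthest compound 1, and both gaps are within the scatter. No ordering among the three is therefore claimed.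

Compound 4 `O=C(C1CCC2(CCC2)CC1)N1CC(c2nc(-c3cccc(Cl)c3)no2)C1` differs from compound 2 at the carbonyl carbon: a group of 9 heavy atoms (9 carbon; one four-membered non-aromatic ring of carbon only, one six-membered non-aromatic ring of carbon only) in place of a group of 7 heavy atoms (7 carbon; one six-membered non-aromatic ring of carbon only), on a carbonyl carbon. Among the measured compounds shown here, the only measured step at the same place is a 1.5-fold lower number from compound 2 to compound 3 (0.18 log units; within the scatter), a change on the saturated ring of the amide that stayed within the scatter. Nothing measured addresses a second ring at that position, so the expectation rests on that single step: no move beyond the scatter in this assay, with at most a small shift toward lower numbers.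

Compound 4 is therefore estimated at 1200 nM in this assay, with a range from 500 nM to 3000 nM; this corresponds to an expected step of a 1.3-fold lower number from compound 2 to compound 4 (0.10 log units; within the scatter).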

Compound 4, half-maximal effective concentration: 1100 nM
For compound 4 the middle estimate is 1.1-fold (0.04 log units) above the measured one; the measured number falls inside the stated range.
By their numbers in this assay, from the lowest: compounds 3, 4, 2 and 1 (each within the scatter of the next, the first and the last beyond it).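

In this assay the group with a second, four-membered ring of carbon only, in place of 4-methylcyclohexyl on the carbonyl carbon, comes with a 1.4-fold lower number from compound 2 to compound 4 (0.13 log units; within the scatter) and so shows that two more heavy atoms and an added ring at this place leave the number within the scatter. With a 1.5-fold lower number from compound 2 to compound 3 (0.18 log units; within the scatter) on record, two unlike changes to the saturated amide group now stay within the scatter, and no order between them is claimed. No independent measurement is available to explain this result.

On these data alone, whether an amine or a carboxylic acid on the saturated ring, or a longer chain in its place, would move the number beyond the scatter remains open. Compound 1 differs from compound 2 in more than one place, so the effect of its 4-chlorophenyl group at the carbonyl carbon also remains unresolved.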